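Pyrrolidine ether series: amine nitrogen substituent, compound 4

A few compounds are considered here, and "the series" means these few. Any claim that something is new, unique, unknown or untested is made for them only; others in the source may bear on it.

Compound 1 `C[C@@H](O[C@@H]1CN(C=O)C[C@H]1c1ccc(F)cc1)c1cc(C(F)(F)F)cc(C(F)(F)F)c1`, compound 2 `C[C@@H](O[C@@H]1CN(C(=O)C(C)(C)C)C[C@H]1c1ccccc1)c1cc(C(F)(F)F)cc(C(F)(F)F)c1` and compound 3 `CC(=O)N1CCC(C(=O)N2C[C@@H](O[C@H](C)c3cc(C(F)(F)F)cc(C(F)(F)F)c3)[C@H](c3ccc(F)cc3)C2)CC1` share the same core and differ at the amine nitrogen in the ring and in the phenyl group. In an assay on CHO cells for displacement of a labelled ligand from Substance-P receptor (Homo sapiens) (a higher number here means a weaker inhibitor, a lower number a stronger inhibitor), compound 1 gives 0.24 nM, compound 2 gives 0.18 nM and compound 3 gives 0.07 nM. Compound 2 therefore holds the second highest number of the three: its gap to compound 1 lies within the scatter, while compound 3 sits beyond the scatter with the lower number. Going by the values given here, the only single-point step in hand is a 3.4-fold lower number from compound 1 to compound 3 (0.54 log units; beyond the scatter), a modest shift from a larger group on the carbonyl carbon.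

Compound 4 `C[C@@H](O[C@@H]1CN(C2=CC(=O)C(C)(C)CC2)C[C@H]1c1ccccc1)c1cc(C(F)(F)F)cc(C(F)(F)F)c1` is compound 2 with 4,4-dimethyl-3-oxocyclohex-1-en-1-yl in place of (tert-butyl)carbonyl on an amine nitrogen in a ring. The entering group is larger than the leaving one and brings a six-membered ring where there was none. The step from compound 1 to compound 3 touched the same region and shows that enlarging the group on the amine nitrogen did not raise the number. Among the compounds with values here, no measured step covers exchanging the carbonyl on that nitrogen itself, so the expectation for compound 4 is a change of a 1.7-fold higher number from compound 2 to compound 4 (0.22 log units; within the scatter), within or close to the scatter. Compound 4 is estimated at 0.3 nM, with a range of 0.1 nM to 1 nM.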

Compound 4, half-maximal inhibitory concentration: 0.18 nM
The estimate for compound 4 lay 1.7-fold (0.22 log units) above the measured number, and the stated range covers the measured number.
By their numbers in this assay, from the lowest: compound 3; then compounds 2, 4 and 1 (each within the scatter of the next).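

In this assay, 4,4-dimethyl-3-oxocyclohex-1-en-1-yl in place of (tert-butyl)carbonyl on the amine nitrogen in the ring gives no change at the digits printed from compound 2 to compound 4 (within the scatter), even though the count of heavy atoms in the group rises from 6 to 9 and a six-membered ring of carbon enters. Going by these compounds alone, compounds 1, 2 and 3 all carry a carbonyl directly on this nitrogen, so compound 4 adds the first reading without one: in this pair, with the phenyl group unchanged, the number holds when a ring carbon takes that place and the oxygen sits further out in the group. Nothing at hand bears on why the number holds across this change.

The compounds shown leave open whether the ring ketone or the two methyl groups of the entering group matter to the number, and whether the group behaves alike with the 4-fluorophenyl present in compound 1. Also open, from the compounds shown here alone, is how this nitrogen responds to a plain alkyl chain, a chain ending in a carboxylic acid, or a lone hydrogen.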